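Second trifluoromethyl on the urea aryl of compound 2

The compounds below may be only part of what the source reports. "The series", "measured", "known", "first", "only" and "open" are said of these compounds alone.

Compound 2 `COc1cc(-c2nn(-c3cccc(NC(=O)Nc4cccc(C(F)(F)F)c4)c3)cc2-c2ccncc2)ccc1Cl` gives 306 nM in a functional assay on SF-295 cells (Homo sapiens) for inhibition, read by sulforhodamine B assay, with a stated time of 48 h (on this read-out higher numbers stand for weaker inhibition of growth and lower numbers for stronger inhibition of growth), the lowest of the three numbers measured. Compound 3 `COc1cc(-c2nn(-c3cccc(NC(=O)c4ccccc4)c3)cc2-c2ccncc2)ccc1Cl` gives 337 nM, and the step of a 1.1-fold higher number from compound 2 to compound 3 (0.04 log units; within the scatter) lies within the scatter. Compound 1 `O=C(Nc1cccc(-n2cc(-c3ccncc3)c(-c3ccc(Cl)c(O)c3)n2)c1)Nc1cc(C(F)(F)F)cc(C(F)(F)F)c1` gives 618 nM, which stands beyond the scatter from compound 2 but differs from it in two places. Compound 4 `COc1cc(-c2nn(-c3cccc(NC(=O)Nc4cc(C(F)(F)F)cc(C(F)(F)F)c4)c3)cc2-c2ccncc2)ccc1Cl` carries the change (trifluoromethyl in place of hydrogen on an aromatic carbon). Within the data shown here, no measured step isolates this change; compound 1 shows only that a bis-trifluoromethyl urea with a hydroxy group gives a weaker number. The step of a 1.4-fold higher number from compound 2 to compound 4 (0.14 log units; within the scatter) is therefore expected to be small, leaning toward weaker inhibition. Compound 4 is estimated at 420 nM, within 200 nM to 900 nM.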

Compound 4, concentration for 50% growth inhibition: 399 nM
Compound 4: middle estimate off by 1.1-fold (0.02 log units), on the high side; the measured number falls inside the stated range.
By their numbers in this assay, from the lowest: compounds 2, 3, 4 and 1 (each within the scatter of the next, the first and the last beyond it).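

In this assay, trifluoromethyl in place of hydrogen on this aromatic carbon, meta to a trifluoromethyl group, gives a 1.3-fold higher number from compound 2 to compound 4 (0.12 log units; within the scatter), so this position takes the second group with a step within the scatter. Compound 4 also supplies a single-place comparison for compound 1: methyl in place of hydrogen on an oxygen on an aromatic ring gives a 1.5-fold lower number from compound 1 to compound 4 (0.19 log units; within the scatter), again within the scatter. No measured evidence accounts for either step. The compounds shown leave open whether an amine or a carboxylic acid on this aromatic carbon would stay within the scatter of compound 2.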